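Phenyltriazole in place of the imide on the aromatic ring

The compounds below may be only part of what the source reports. "The series", "measured", "known", "first", "only" and "open" are said of these compounds alone.

Compound 1 `CC1(C)CC(=O)N(c2ccccc2C(=O)OCC2CCCN(CCCc3ccccc3)C2)C1=O` — 5010 nM
Compound 2 `O=C(OCC1CCCN(CCCc2ccccc2)C1)c1ccccc1-c1ccccc1` — 100000000 nM; > 100000 nM (2 entries)

For the measured compounds named here, in an in vitro functional assay on HEK ts201 cells for antagonist activity at Neuronal acetylcholine receptor; alpha3/beta4 (Homo sapiens), read by fluorescence and calcium flux (on this read-out lower numbers stand for stronger inhibition and higher numbers for weaker inhibition), compound 1 gives 5010 nM, the only plain number among the measured compounds. Compound 2 gives 100000000 nM; > 100000 nM (2 entries) over its several entries. Compound 3 `O=C(OCC1CCCN(CCCc2ccccc2)C1)c1ccccc1-n1cc(-c2ccccc2)nn1` is not yet measured; it differs from compound 1 by 4-phenyl-1H-1,2,3-triazol-1-yl in place of 3,3-dimethyl-2,5-dioxopyrrolidin-1-yl on an aromatic carbon. Going by the values given here, no step between two measured compounds is available to anchor this change. The expectation for compound 3 is a loss of potency, a step of a 4.0-fold higher number from compound 1 to compound 3 (0.60 log units; beyond the scatter) that is estimated to lie beyond the usual scatter. Compound 3 is therefore expected at 20000 nM, within 4000 nM to 100000 nM.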

Compound 3, half-maximal inhibitory concentration: 4270 nM
Compound 3: the middle estimate sits 4.7-fold (0.67 log units) above what was measured; measured number inside the range.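

In this assay, for the compounds shown here, the exchange gives a 1.2-fold lower number from compound 1 to compound 3 (0.07 log units; within the scatter): at this place, on an aromatic carbon, the 3,3-dimethyl-2,5-dioxopyrrolidin-1-yl group is thus not the only group compatible with this level of inhibition. Not every aromatic group at this place gives a comparable reading, and the step to compound 2 cannot be read, since its entries include a limit and disagree: the several entries of compound 2 in this assay, 100000000 nM; > 100000 nM (2 entries)

The compounds shown leave open whether the triazole without its phenyl ring would give a comparable value. They also leave open how an amine or a carboxylic acid on that phenyl ring would read.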